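A few compounds are considered here, and "the series" means these few. Any claim that something is new, unique, unknown or untested is made for them only; others in the source may bear on it.

Measured so far:
compound 1, `CCNC(=O)/C=C(C)/C=C/CC(C)CCCC(C)C` — in a physicochemical assay for lipophilicity (a lower number here means a more polar compound, a higher number a more lipophilic compound), compound 1 gives 5.24
compound 2, `CCN(CC)C(=O)/C=C(C)/C=C/CC(C)CCCC(C)C` — compound 2 gives 6.02
compound 3, `CCNC(=O)/C=C(C)/C=C/CC(C)CCC=C(C)C` — compound 3 gives 4.69

Compound 3 has the lowest of the three numbers. Two steps link these compounds. From compound 1 to compound 2 the change is ethyl in place of hydrogen on an amide-type nitrogen, and it made a number 0.78 log units higher from compound 1 to compound 2 (beyond the scatter). From compound 1 to compound 3 the change made a number 0.55 log units lower from compound 1 to compound 3 (beyond the scatter).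

Compound 4, `CCN(CC)C(=O)/C=C(C)/C=C/CC(C)CCC=C(C)C`, has not yet been measured in this assay. It differs from compound 3 by ethyl in place of hydrogen on an amide-type nitrogen. This is the same change as the one from compound 1 to compound 2, and the place it sits on is described in the same words in both pairs; among the compounds shown it occurs twice. The two cores, that of compound 1 and that of compound 3, differ by 2-methylprop-1-en-1-yl in place of isobutyl on a saturated chain carbon, four bonds along the chain from a double-bonded chain carbon.

On this basis a step of about a number 0.78 log units higher from compound 3 to compound 4 (beyond the scatter) is expected from compound 3 to compound 4, close to the earlier one, because compound 1 to compound 2 gave a number 0.78 log units higher from compound 1 to compound 2 (beyond the scatter). Compound 4 is therefore estimated at 5.47, expected to fall between 5.15 and 5.8.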

Compound 4, partition coefficient: 5.47
Estimate against measurement, compound 4: no gap at the digits printed; low and high end bracket the measured number.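

In this assay, ethyl in place of hydrogen on the amide-type nitrogen gave a number 0.78 log units higher from compound 3 to compound 4 (beyond the scatter), the same size as a number 0.78 log units higher from compound 1 to compound 2 (beyond the scatter), and read the other way the chain change gave a number 0.55 log units lower from compound 2 to compound 4 (beyond the scatter), the same size as a number 0.55 log units lower from compound 1 to compound 3 (beyond the scatter), so in these four compounds the two changes add up with no gap at the digits printed. This rests on one change carried between just two cores that differ in a single place, so it shows that the step held here and does not show that it would hold on any other core or in any other assay. Nothing available accounts for the step keeping its size, and no reason for it can be offered.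

The compounds shown leave open what a longer chain such as butyl would give in place of ethyl on the amide-type nitrogen. They also leave open whether the step would keep its size on a core carrying an amine or a carboxylic acid.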